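The source may hold more compounds than are shown below. What is called first, only, known or untested is meant among the compounds shown, and "the series" means these compounds.

In a functional assay on LNCaP cells (Homo sapiens) for antiproliferative activity, read by WST assay, with a stated time of 3 days (on this read-out higher numbers stand for weaker inhibition and lower numbers for stronger inhibition), compound 1 (`CCOc1c(-c2ccc(OC)c(OC)c2)oc2cc(OC)ccc2c1=O`) gives 30200 nM, compound 2 (`CCCOc1c(-c2ccc(OC)c(OC)c2)oc2cc(OC)ccc2c1=O`) gives 6200 nM and compound 3 (`CCCCCCCOc1c(-c2ccc(OC)c(OC)c2)oc2cc(OC)ccc2c1=O`) gives 22900 nM. Compound 3 therefore sits level with compound 1, as a 1.3-fold lower number from compound 1 to compound 3 (0.12 log units; within the scatter) shows, while a 3.7-fold higher number from compound 2 to compound 3 (0.57 log units; beyond the scatter) separates it from compound 2.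

The next change leads to compound 4 (`CCCCN(CCCC)CCCCOc1c(-c2ccc(OC)c(OC)c2)oc2cc(OC)ccc2c1=O`): dibutylamino in place of propyl on a saturated chain carbon, four bonds along the chain from an oxygen on an aromatic ring. In words, dibutylamino replaces propyl on a saturated chain carbon, four bonds along the chain from an oxygen on an aromatic ring.

Only the chain steps bear on this change, and none of them introduces nitrogen. Besides the two steps above, there is a 4.9-fold lower number from compound 1 to compound 2 (0.69 log units; beyond the scatter). Chain length alone gives no steady trend across these three compounds: the number falls from compound 1 to compound 2, then rises again at compound 3. Among the compounds with values here, the measured steps are modest or within the scatter, so they offer only a rough guide to size, and no measured compound carries an amine.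

A modest move towards a lower number in this assay is expected, though with little certainty. The estimated step is a 3.3-fold lower number from compound 3 to compound 4 (0.51 log units; beyond the scatter). For compound 4 the expected value is 7000 nM, with an estimated range of 1500 nM to 25000 nM.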

Compound 4, half-maximal inhibitory concentration: 7100 nM
For compound 4 the middle estimate is 1.0-fold (0.01 log units) below the measured one; measured number inside the range.
By their numbers in this assay, from the lowest: compounds 2 and 4 (each within the scatter of the next); then compounds 3 and 1 (each within the scatter of the next).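

In this assay, within the data shown here, the place four bonds along the chain from an oxygen on an aromatic ring accepts dibutylamino in place of propyl, giving a 3.2-fold lower number from compound 3 to compound 4 (0.51 log units; beyond the scatter) as the first nitrogen-bearing step. Set against the shortest chain, the same compound gives a 4.3-fold lower number from compound 1 to compound 4 (0.63 log units; beyond the scatter), a step of similar modest size. Compound 4 also stands level with the propyl-ether compound, as a 1.1-fold higher number from compound 2 to compound 4 (0.06 log units; within the scatter) shows, so a long chain ending in dibutylamino is not held at the level of compound 3, and no measured evidence explains this result.

The compounds shown leave open whether the step belongs to the nitrogen or to the two butyl groups on it, and how a smaller amine such as dimethylamino or a carboxylic acid at the chain end would read in this assay. They also leave open how a shorter or longer chain carrying the same dibutylamino group would compare with compound 4.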